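Methoxy-to-chloro exchange on the N-aryl of the lactam

The source may report more compounds than this note shows. Statements on the series, on what has been measured and on what is new or still open speak of the compounds shown alone.

Measured so far:
Compound 1 `COc1ncc(-c2ccc3c(c2)NC(=O)CO3)cc1NS(=O)(=O)c1ccc(F)cc1`: 7110 nM
Compound 2 `O=C1COc2ccc(-c3cnc(Cl)c(NS(=O)(=O)c4ccc(F)cc4)c3)cc2N1`: 15600 nM
Compound 3 `COc1ccc(N2C(=O)COc3ccc(-c4cnc(OC)c(NS(=O)(=O)c5ccc(F)cc5)c4)cc32)cc1`: 1220 nM

All values come from a functional assay on HeLa cells (Homo sapiens) for antiproliferative activity, read by MTT assay, with a stated time of 72 h; on this read-out higher numbers stand for weaker inhibition and lower numbers for stronger inhibition. Compound 3 differs from compound 1 by 4-methoxyphenyl in place of hydrogen on an amide-type nitrogen in a ring, a change that gives a 5.8-fold lower number from compound 1 to compound 3 (0.77 log units; beyond the scatter). Compound 2 differs from compound 1 by chloro in place of methoxy on an aromatic carbon, which gives a 2.2-fold higher number from compound 1 to compound 2 (0.34 log units; beyond the scatter).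

Compound 4 `COc1ncc(-c2ccc3c(c2)N(c2ccc(Cl)cc2)C(=O)CO3)cc1NS(=O)(=O)c1ccc(F)cc1` is not yet measured. It differs from compound 3 by chloro in place of methoxy on an aromatic carbon. This is the same kind of change as from compound 1 to compound 2, but the surroundings differ: there the group sat next to the ring nitrogen, ortho to a large group and para to a large group; here it sits on a ring of carbon only, para to a large group. Because a 2.2-fold higher number from compound 1 to compound 2 (0.34 log units; beyond the scatter) was modest, compound 4 is expected to follow compound 3 with a modest step, a 1.6-fold higher number from compound 3 to compound 4 (0.19 log units; within the scatter). The estimate for compound 4 in this assay is 1900 nM, between 600 nM and 6000 nM.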

Compound 4, half-maximal inhibitory concentration: 4830 nM
For compound 4 the middle estimate is 2.5-fold (0.41 log units) below the measured one, within the range that was stated.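

In this assay, chloro in place of methoxy gives a higher number on both cores, and the two steps agree: the same change on two cores in this assay, a 2.2-fold higher number (0.34 log units; beyond the scatter) from compound 1 to compound 2 and a 4.0-fold higher number (0.60 log units; beyond the scatter) from compound 3 to compound 4, 1.8-fold (0.26 log units) apart, within the scatter of two such steps. On the aryl group of the lactam the exchange gives a 4.0-fold higher number from compound 3 to compound 4 (0.60 log units; beyond the scatter), while 4-chlorophenyl in place of hydrogen on the amide-type nitrogen gives a 1.5-fold lower number from compound 1 to compound 4 (0.17 log units; within the scatter), so compound 4 is not told apart from compound 1. Two pairs show that the step carried over in direction and size between these two sites only; they do not show that it would hold on other cores or at other positions.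

Open, going by these compounds, is how an amine or a carboxylic acid would read in place of methoxy on the 4-methoxyphenyl ring. Also open, on these data alone, is whether a longer chain on the amide-type nitrogen would match the aryl groups of compound 3 and compound 4.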